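Three Inactive Amides and a Fourth Untested Combination

The source may hold more compounds than are shown below. What is called first, only, known or untested is meant among the compounds shown, and "the series" means these compounds.

compound 1 `C=CC1=C(C(=O)Nc2ccccc2OC)C(c2ccc(F)cc2)OC1`: > 100000 nM
compound 2 `C=CC1=C(C(=O)Nc2ccc(C)cc2)C(c2ccc(F)cc2)OC1`: > 100000 nM
compound 3 `C=CC1=C(C(=O)Nc2ccccc2OC)C(c2ccc(OC)cc2)OC1`: > 100000 nM

In a functional assay on HeLa cells (Homo sapiens) for cytotoxicity, read by MTT assay, with a stated time of 24 h (a higher number here means a weaker inhibitor, a lower number a stronger inhibitor), compound 1 reaches only a limit of the assay, not a number. Compound 2 likewise stops at a limit. Compound 3 also gives a limit. Compound 2 differs from compound 1 by 4-methylphenyl in place of 2-methoxyphenyl on an amide-type nitrogen, and the step is a step that the two limits leave unreadable from compound 1 to compound 2. Compound 3 differs from compound 1 by methoxy in place of fluoro on an aromatic carbon, and that step is a step that the two limits leave unreadable from compound 1 to compound 3. Compound 4 `C=CC1=C(C(=O)Nc2ccc(C)cc2)C(c2ccc(OC)cc2)OC1` differs from compound 3 by 4-methylphenyl in place of 2-methoxyphenyl on an amide-type nitrogen, the same change as from compound 1 to compound 2, made on a core that differs as just told. The step from compound 3 to compound 4 is expected to be a step that the limit leaves unreadable from compound 3 to compound 4, resting on (the limit of > 100000 nM in this assay, at which 3 of the 3 values shown sit). Compound 4 is expected to give about 150000 nM in this assay, between 60000 nM and 400000 nM.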

Compound 4, half-maximal inhibitory concentration: > 100000 nM
Compound 4: only a limit was reported; the forecaster's own chance of this, stated with the estimate: 85%; the middle value does not contradict the limit.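

Compound 4 also stops at a limit, like compound 2 and compound 3, so neither step into it can be read: the limit of > 100000 nM in this assay, at which 4 of the 4 values shown sit.

What the compounds shown leave open is whether any change to the shared core would give a real number rather than a limit.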